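A few compounds are considered here, and "the series" means these few. Any claim that something is new, unique, unknown or untested is made for them only; others in the source may bear on it.

Measured in a functional assay on HepG2 cells (Homo sapiens) for antiproliferative activity, read by MTT assay, with a stated time of 48 h; on this read-out lower numbers stand for stronger inhibition and higher numbers for weaker inhibition:
- compound 1 `O=C(CN1CCCC1)Nc1ccc2ncnc(Nc3ccc(Cl)cc3)c2c1`: 18000 nM
- compound 2 `O=C(CN1CCCCC1)Nc1ccc2ncnc(Nc3ccc(Cl)cc3)c2c1`: 16000 nM
- compound 3 `CN1CCN(CC(=O)Nc2ccc3ncnc(Nc4ccc(Cl)cc4)c3c2)CC1`: > 100000 nM

Going by these compounds, the entry for compound 3 is a limit of the assay and not a number, so its true position on the scale is unknown.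

Compound 4 `CN1CCN(CC(=O)Nc2ccc3ncnc(Nc4cccc(Br)c4)c3c2)CC1` has 3-bromophenyl in place of 4-chlorophenyl on a nitrogen on an aromatic ring. For the measured compounds named here, no measured step makes this kind of change, so none gives its size directly. The steps available change only the saturated ring: a 1.1-fold lower number from compound 1 to compound 2 (0.05 log units; within the scatter) stays within the scatter, while an at least 5.5-fold higher number from compound 1 to compound 3 (0.74 log units; beyond the scatter) and an at least 6.2-fold higher number from compound 2 to compound 3 (0.79 log units; beyond the scatter) go beyond it. Compound 4 keeps the 4-methylpiperazin-1-yl group that came with the higher number in an at least 6.2-fold higher number from compound 2 to compound 3 (0.79 log units; beyond the scatter), so no step beyond the scatter is expected in this assay, in either direction. The estimate amounts to an expected a number no higher from compound 3 to compound 4 (the limit leaves the size open).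

The estimated value for compound 4 is 100000 nM, with an expected range of 25000 nM to 400000 nM.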

Compound 4, half-maximal inhibitory concentration: 25300 nM
For compound 4 the middle estimate is 4.0-fold (0.60 log units) above the measured one, and the stated range covers the measured number.
By their numbers in this assay, from the lowest: compounds 2, 1 and 4 (each within the scatter of the next). At a limit, above all of these: compound 3.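

Earlier steps changed only the saturated ring, while this one changes the aromatic group on the nitrogen: in this assay, 3-bromophenyl in place of 4-chlorophenyl gives an at least 3.9-fold lower number from compound 3 to compound 4 (0.59 log units; beyond the scatter). With 4-methylpiperazin-1-yl kept in both compounds, this place on the molecule can also move the number beyond the scatter. Compound 3 stands at a limit of the assay and not at a number, so the size of this step is known only as a bound because of that entry: the limit of > 100000 nM in this assay, at which 1 of the 4 values shown sits.

The change alters two things at once, the halogen and where it sits on the ring, and only 3-chlorophenyl or 4-bromophenyl on the same nitrogen could tell these apart. Going by these compounds, whether 3-bromophenyl gives a similar step alongside pyrrolidin-1-yl or piperidin-1-yl also stays open.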